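Halogen swap on the benzylidene arm: inactive dichloro to bromo

This account rests on a few compounds, and the source may have more. Where it says the series, first, only, none or still open, it means among the compounds named here.

Measured so far:
- compound 1, `C=CCn1c(=O)/c(=C\c2cccc(F)c2)[nH]c(=O)/c1=C\c1ccccc1OC`: 9100 nM
- compound 2, `C=CCn1c(=O)/c(=C\c2ccc(Cl)c(Cl)c2)[nH]c(=O)/c1=C\c1ccccc1OC`: "not active" (no number reported)

In a functional assay on HeLa cells (Homo sapiens) for cytotoxicity, read by CCK-8 assay, with a stated time of 72 h (a lower number here means a stronger inhibitor, a higher number a weaker inhibitor), compound 1 gives 9100 nM. In this assay compound 2 is reported as "not active" (no number reported), so no single number stands for it and it cannot be placed on the scale beside compound 1; all that the two results show is that compound 1 returned a concentration and compound 2 did not.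

Compound 3, `C=CCn1c(=O)/c(=C\c2cccc(Br)c2)[nH]c(=O)/c1=C\c1ccccc1OC`, has not been measured. It differs from compound 2 as follows: 3-bromophenyl in place of 3,4-dichlorophenyl on a double-bonded chain carbon bound to an aromatic carbon. Among the measured compounds shown here, no step between measured compounds covers this change, and compound 2 has no number from which a step could start. For the measured compounds named here, the only anchor is compound 1, which also carries a single halogen on that ring and gives 9100 nM. Compound 3 is therefore expected to land in the same weak region, with a real chance that this assay again reports only inactivity. The estimate for compound 3 is 12000 nM, with a range from 3000 nM to 50000 nM.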

Compound 3, half-maximal inhibitory concentration: 5400 nM
For compound 3 the middle estimate is 2.2-fold (0.35 log units) above the measured one; low and high end bracket the measured number.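

In this assay, bromo in place of fluoro on an aromatic carbon gives a 1.7-fold lower number from compound 1 to compound 3 (0.23 log units; within the scatter), so the two single-halogen compounds cannot be told apart in this series, and compound 3 at 5400 nM gives a second number for a monohalogenated ring on the double-bonded chain carbon bound to an aromatic carbon. With 3,4-dichlorophenyl at that place compound 2 is reported only as "not active" and with 3-bromophenyl compound 3 returns a concentration, but the step between them cannot be read, since compound 2 has no number to start from. Nothing measured on these compounds speaks to what lies behind these results.

From the compounds shown here alone, it remains open whether the missing number for compound 2 goes with the second chlorine, with chlorine as the halogen, or with the 3,4-dichloro arrangement as a whole, and a 3-chlorophenyl or 4-bromophenyl ring would separate these readings. Also open, going by these compounds, is whether a ring carrying an amine or a carboxylic acid instead of a halogen at that place would return a number in this assay at all.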